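Replacing the diethylamino group of compound 3

The source may report more compounds than this note shows. Statements on the series, on what has been measured and on what is new or still open speak of the compounds shown alone.

In an ADME assay on L6 cells (Rattus norvegicus) for cytotoxicity, read by resazurin assay, with a stated time of 72 h (a lower number here means a stronger inhibitor, a higher number a weaker inhibitor), compound 3 (`CCN(CC)c1ccc(C(=O)NC(=O)c2ccccc2O)cc1`) gives 8.2 ug/mL and sits in the middle, with compound 1 (`CC(C)(C)c1ccc(C(=O)NC(=O)c2ccccc2O)cc1`) at 2.3 ug/mL and compound 2 (`CN(C)c1ccc(C(=O)NC(=O)c2ccccc2O)cc1`) at 54 ug/mL on either side. Compound 4 (`COC(=O)CCC(=O)Nc1ccc(C(=O)NC(=O)c2ccccc2O)cc1`) carries ((2-(methoxycarbonyl)ethyl)carbonyl)amino in place of diethylamino on an aromatic carbon. The measured steps swap groups at that same place, and they span a wide range: a 23-fold higher number from compound 1 to compound 2 (1.37 log units; beyond the scatter) and a 3.6-fold higher number from compound 1 to compound 3 (0.55 log units; beyond the scatter) and also a 6.6-fold lower number from compound 2 to compound 3 (0.82 log units; beyond the scatter) in the opposite direction. None brings in a group like the new one, so the guide is loose. A modest rise is expected, matching the upward steps from compound 1. The expected change is a 3.0-fold higher number from compound 3 to compound 4 (0.48 log units; beyond the scatter) and remains only an estimate. Compound 4 is estimated at 25 ug/mL within an expected range from 7 ug/mL to 80 ug/mL in this series.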

Compound 4, half-maximal inhibitory concentration: > 50 ug/mL
Compound 4: only a limit was reported (the forecaster's own chance of this, stated with the estimate: 10%); middle value at least 2.0-fold (0.30 log units) from the limit.
By their numbers in this assay, from the lowest: compound 1; then compound 3; then compound 2.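

In this assay, compound 4 is reported only as a limit, > 50 ug/mL, and not as a number. Even so, the limit gives an at least 6.0-fold higher number from compound 3 to compound 4 (0.78 log units; beyond the scatter), and also an at least 21-fold higher number from compound 1 to compound 4 (1.33 log units; beyond the scatter), while the step involving compound 2 cannot be read. This shows that a long chain containing oxygen atoms, unlike the groups in compounds 1 and 3, can carry the number well upward at this place on the aromatic ring.

The compounds shown leave open how high the number of compound 4 truly lies. They also leave open which part of the chain matters, since a shorter acetylamino group or a free carboxylic acid in place of the methyl ester would separate the two.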